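The source may hold more compounds than are shown below. What is called first, only, known or untested is meant among the compounds shown, and "the series" means these compounds.

Measured compounds in a functional assay on K562 cells (Homo sapiens), read by MTT assay, with a stated time of 72 h; on this read-out lower numbers stand for stronger inhibition and higher numbers for weaker inhibition:
- compound 1 `Nc1nc(N)c2c(-c3ccsc3)cn([C@@H]3O[C@H](CO)[C@@H](O)[C@H]3O)c2n1`: > 20000 nM (a limit of this assay, not a number)
- compound 2 `COc1ncnc2c1c(-c1ccsc1)cn2[C@@H]1O[C@H](CO)[C@@H](O)[C@H]1O`: 90 nM
- compound 3 `CN(C)c1ncnc2c1c(-c1ccsc1)cn2[C@@H]1O[C@H](CO)[C@@H](O)[C@H]1O`: 530 nM

Compound 2 stands lowest of the two numbers reported; the nearest is compound 3, separated by a 5.9-fold higher number from compound 2 to compound 3 (0.77 log units; beyond the scatter). Compound 1 reaches only (the limit of > 20000 nM in this assay, at which 1 of the 3 values shown sits), so for it no number is known.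

Compound 4 `COc1nc(N)nc2c1c(-c1ccsc1)cn2[C@@H]1O[C@H](CO)[C@@H](O)[C@H]1O` is not yet measured. It differs from compound 2 by amino in place of hydrogen on an aromatic carbon. Among the compounds with values here, the one measured step, from compound 2 to compound 3, concerns a different change and so does not bear directly on this one. Within the data shown here, what can be set beside it is only that compound 2 gives 90 nM. Compound 1, which carries an amino group at this same place along with a further change, reaches only a limit in this assay. On that basis the expected step is a 22-fold higher number from compound 2 to compound 4 (1.35 log units; beyond the scatter), a weakening, with a real chance that only a limit is reported. The estimate for compound 4 is 2000 nM, with a range from 300 nM to 20000 nM.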

Compound 4, half-maximal inhibitory concentration: > 20000 nM
Compound 4 was reported as a limit; the forecaster's own chance of this, stated with the estimate: 25%; middle value at least 10-fold (1.00 log units) from the limit.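

In this assay, placing an amino group on the aromatic carbon between two ring nitrogen atoms of compound 2 gives an at least 220-fold higher number from compound 2 to compound 4 (2.34 log units; beyond the scatter), a large loss of activity from this one change alone. Compound 4 gives > 20000 nM, which is a limit and not a number. Compound 1 carried an amino group here together with a further change, so it could not show what the amino group did alone, and although the step between compound 1 and compound 4 cannot be read, both compounds end at the same limit: the limit of > 20000 nM in this assay, at which 2 of the 4 values shown sit.

The compounds shown leave open whether a methyl group, a chlorine atom or a methylamino group at this place would be tolerated. They also leave open how an amino group here would behave with the dimethylamino group of compound 3.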